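Bromo substitution on compound 2: expected paw edema inhibition

This account rests on a few compounds, and the source may have more. Where it says the series, first, only, none or still open, it means among the compounds named here.

Measured so far, in a functional assay on the whole organism for inhibition, with Rattus norvegicus as the target, read by paw edema, with a stated time of 2 h, at a dose of 50 mg/kg; on this read-out higher numbers stand for more inhibition at the one dose given (going by the name of the read-out) and lower numbers for less inhibition:
- compound 1 `CC(=O)c1c(NNc2nc(C)cc(C)n2)cc(C)oc1=O`: 61.8%
- compound 2 `Cc1cc2nn(-c3ccccc3)c(C)c2c(=O)o1`: 55.1%

Going by the values given here, compound 2 stands at the lowest of the two numbers so far; the nearest, compound 1, lies within the scatter of it, so the two cannot be told apart on this read-out. Among the compounds with values here, no step between measured compounds that differ in one place is available, so there is no measured step to lean on for the change now under consideration.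

Compound 3 `Cc1cc2nn(-c3ccc(Br)cc3)c(C)c2c(=O)o1` is the next compound, not yet measured in this assay. It differs from compound 2 in one place: bromo in place of hydrogen on an aromatic carbon.

Within the data shown here, nothing among the measured compounds shows how bromo in place of hydrogen on an aromatic carbon moves this read-out. The expectation is therefore a step of no size beyond the scatter, a number 1.9 percentage points higher from compound 2 to compound 3 (within the scatter), in either direction. Compound 3 is estimated to give 57% in this assay, with a range from 40% to 72%.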

Compound 3, a percentage reported as inhibition, in the whole organism at one dose (the size of the read-out at that dose, not a potency): 50.6%
The estimate for compound 3 lay 6.4 percentage points above the measured number; the range from low to high includes it.
By their numbers in this assay, from the lowest: compounds 3, 2 and 1 (each within the scatter of the next, the first and the last beyond it).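

The series now has its first step between compounds that differ in one place: in this assay, bromo in place of hydrogen on an aromatic carbon, para to a large group, gives a number 4.5 percentage points lower from compound 2 to compound 3 (within the scatter) and so leaves the two compounds indistinguishable on this read-out. Going by these compounds alone, this position on the six-membered aromatic ring of carbon only therefore takes a single bromine atom without a change that can be told apart from the usual scatter, which the earlier compounds could not show. Nothing available bears on why the read-out stays within the scatter after this change.

As far as these compounds go, it remains open whether a group of another kind at this same position, such as an amine, a carboxylic acid or a longer chain, would move the inhibition beyond the scatter. From the compounds shown here alone, it is also open whether bromo on another carbon of that ring would behave as it does here, and whether the result at this one dose and time would hold at other doses or times.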